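The source may report more compounds than this note shows. Statements on the series, on what has been measured and on what is new or still open speak of the compounds shown alone.

Compound 1 `COc1ccc(C2(CCN3CCC(C(=O)c4nc5ccccc5[nH]4)CC3)CCN(C(=O)c3cc(OC)c(OC)c(OC)c3)C2)cc1OC` gives 6.98 nM in a functional assay for antagonist activity at Substance-P receptor (Cavia porcellus); on this read-out lower numbers stand for stronger inhibition and higher numbers for weaker inhibition.
Compound 2 `CCOCCn1c(C(=O)C2CCN(CCC3(c4ccccc4)CCN(C(=O)c4cc(OC)c(OC)c(OC)c4)C3)CC2)nc2ccccc21` gives 7.59 nM in this assay.

Compound 2 stands at the top of these two numbers, yet its gap to compound 1 lies within the usual scatter, so the two are not separated. Compound 3 `CCOCCn1c(C(=O)C2CCN(CCC3(c4ccc(OC)c(OC)c4)CCN(C(=O)c4cc(OC)c(OC)c(OC)c4)C3)CC2)nc2ccccc21` differs from compound 2 by a single change: 3,4-dimethoxyphenyl in place of phenyl on a saturated ring carbon. For the measured compounds named here, no step between measured compounds bears on this change, and compound 1, which carries that same group on a different ring, sits close to compound 2. Compound 3 is therefore expected to show no shift beyond the scatter, a 1.2-fold lower number from compound 2 to compound 3 (0.07 log units; within the scatter), with an estimate of 6.5 nM (range 2.5 nM to 18 nM).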

Compound 3, half-maximal inhibitory concentration: 7.39 nM
The estimate for compound 3 lay 1.1-fold (0.06 log units) below the measured number; the range from low to high includes it.
By their numbers in this assay, from the lowest: compounds 1, 3 and 2 (each within the scatter of the next).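

In this assay, 3,4-dimethoxyphenyl in place of phenyl on the saturated ring carbon gives a 1.0-fold lower number from compound 2 to compound 3 (0.01 log units; within the scatter), so with 2-ethoxyethyl on the aromatic nitrogen, these two groups are not separated at this position. The aromatic nitrogen behaves alike: 2-ethoxyethyl in place of hydrogen gives a 1.1-fold higher number from compound 1 to compound 3 (0.02 log units; within the scatter), a single-place comparison that compounds 1 and 2 alone could not offer. Nothing measured here speaks to the reason for either result.

For the compounds shown here, each position is tested with only one change. As far as these compounds go, whether an amine or a carboxylic acid on that phenyl, or a longer chain in place of 2-ethoxyethyl, would also leave the number within the scatter remains open.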